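A few compounds are considered here, and "the series" means these few. Any claim that something is new, unique, unknown or untested is made for them only; others in the source may bear on it.

Measured compounds:
compound 1, `C=CCNC(=O)n1c(-c2ccc(OC)cc2)cc(=O)c2c(OC)cc(OC)cc21` — > 20000 nM
compound 2, `COc1ccc(-c2cc(=O)c3c(OC)cc(OC)cc3n2S(=O)(=O)c2ccc(C)c([N+](=O)[O-])c2)cc1` — > 51700 nM
compound 3, `COc1ccc(-c2cc(=O)c3c(OC)cc(OC)cc3n2S(=O)(=O)c2cc(Cl)cc(Cl)c2O)cc1` — > 37900 nM

In a functional assay on HepG2 cells (Homo sapiens) for antiproliferative activity, with a stated time of 72 h (a lower number here means that less compound is needed, a higher number that more compound is needed for the effect), compound 1 reaches only a limit of the assay, > 20000 nM. Compound 2 likewise gives only a limit, > 51700 nM. Compound 3 also gives only a limit, > 37900 nM. Compound 3 thus stands at one of three limits, and among the three compounds no order can be read. The step that the two limits leave unreadable from compound 2 to compound 3 carries no readable size because the limit of > 51700 nM in this assay, at which 1 of the 3 values shown sits, and the limit of > 37900 nM in this assay, at which 1 of the 3 values shown sits, are both limits rather than numbers.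

Compound 4, `COc1ccc(-c2cc(=O)c3c(OC)cc(OC)cc3n2S(=O)(=O)c2ccc(Br)s2)cc1`, has not yet been measured in this assay. It differs from compound 3 by 5-bromothiophen-2-yl in place of 3,5-dichloro-2-hydroxyphenyl on a sulfonyl sulfur. Within the data shown here, the only measured step at the sulfonyl sulfur, a step that the two limits leave unreadable from compound 2 to compound 3, gives no size, so nothing among the measured steps sets a direction for this change. The expectation therefore rests on compound 3 sitting at a limit, > 37900 nM, and on no step beyond the scatter being expected, which is what a step that the limit leaves unreadable from compound 3 to compound 4 is taken to mean. Compound 4 is estimated at 40000 nM, with a range from 10000 nM to 200000 nM, and most likely again only a limit.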

Compound 4, half-maximal effective concentration: > 48200 nM
Compound 4 was reported as a limit; the forecaster's own chance of this, stated with the estimate: 75%; middle value at least 1.2-fold (0.08 log units) away from the limit.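

In this assay compound 4 gives only a limit, > 48200 nM. The steps to compound 4 from compound 1, compound 2 and compound 3 cannot be read, and no order among the four compounds can be stated. The compounds shown leave open which group on the sulfonyl sulfur or aromatic nitrogen, if any, would give a measurable value in this assay.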